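The source may report more compounds than this note shows. Statements on the series, on what has been measured and on what is new or still open speak of the compounds shown alone.

Compound 3 `CN1CCN(c2cnc3[nH]cc(-c4cccc(C#N)c4)c3c2)CC1` stands highest of the three compounds measured in a physicochemical assay for solubility, read by LC-MS, in phosphate buffer, measured as thermodynamic solubility, with a stated time of 24 h, at pH 7.4 (a higher number here means a more soluble compound, a lower number a less soluble compound), where compound 3 gives 230000 nM. Compound 1 `N#Cc1cccc(-c2c[nH]c3ncc(-c4cn[nH]c4)cc23)c1` gives 26000 nM in this assay, and compound 2 `Cc1nn(C)c(C)c1-c1cnc2[nH]cc(-c3cccc(C#N)c3)c2c1` gives 5700 nM. The steps up to the top compound were an 8.8-fold higher number from compound 1 to compound 3 (0.95 log units; beyond the scatter) and a 40-fold higher number from compound 2 to compound 3 (1.61 log units; beyond the scatter), while between the two lower compounds the step was a 4.6-fold lower number from compound 1 to compound 2 (0.66 log units; beyond the scatter).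

Compound 4 `Cn1cc(Nc2cnc3[nH]cc(-c4cccc(C#N)c4)c3c2)cn1` carries (1-methyl-1H-pyrazol-4-yl)amino in place of 4-methylpiperazin-1-yl on an aromatic carbon. The entering group shares its five-membered aromatic ring with two hetero atoms with the groups of compound 1 and compound 2, both of which lie well below compound 3 in this assay. The steps from compound 1 and from compound 2 to compound 3 therefore bear on this change; both ran towards a higher number at compound 3, so a step back down is expected here, of a size a 9.2-fold lower number from compound 3 to compound 4 (0.96 log units; beyond the scatter), landing nearer compound 1 than compound 2. Compound 4 is thus expected to give 25000 nM in this assay, within a range from 6000 nM to 90000 nM.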

Compound 4, solubility: 31000 nM
For compound 4 the middle estimate is 1.2-fold (0.09 log units) below the measured one, within the range that was stated.
By their numbers in this assay, from the lowest: compound 2; then compounds 1 and 4 (each within the scatter of the next); then compound 3.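

In this assay the (1-methyl-1H-pyrazol-4-yl)amino group reads level with the unsubstituted 1H-pyrazol-4-yl group (a 1.2-fold higher number from compound 1 to compound 4 (0.08 log units; within the scatter)), so adding the amino link and the ring methyl together leaves no change that stands out from the scatter. The same entering group sits well clear of the 1,3,5-trimethyl-1H-pyrazol-4-yl group (a 5.4-fold higher number from compound 2 to compound 4 (0.74 log units; beyond the scatter)), which shows that a five-membered aromatic ring with two hetero atoms at this position does not fix a single level. It still falls short of the 4-methylpiperazin-1-yl group (a 7.4-fold lower number from compound 3 to compound 4 (0.87 log units; beyond the scatter)), and this group now stands clear of all three pyrazole-bearing compounds. Going by these compounds, whether a morpholine or a longer chain ending in an amine would reach compound 3 stays open, as does the separate share of the amino link and the ring methyl. Nothing given here accounts for these steps.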